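Alkyl size on the far ring: methyl to tert-butyl

This account rests on a few compounds, and the source may have more. Where it says the series, first, only, none or still open, it means among the compounds named here.

Working notes on the series. All three measured compounds share one core and differ only in the group on the terminal six-membered ring. Compound 3 `Cc1ccc(-c2ccc(-c3ccc(C(=N)N)cc3)o2)cc1` carries a methyl; in an assay on isolated protein for inhibition of ribosyldihydronicotinamide dehydrogenase [quinone] (Homo sapiens), read by spectrophotometry, with a stated time of 1 min, in the absence of a further agent (a higher number here means a weaker inhibitor, a lower number a stronger inhibitor), compound 3 gives 72 nM. Compound 1 `CCc1ccc(-c2ccc(-c3ccc(C(=N)N)cc3)o2)cc1` carries an ethyl, and in this assay compound 1 gives 202 nM. Compound 2 `N=C(N)c1ccc(-c2ccc(-c3ccc([N+](=O)[O-])cc3)o2)cc1` carries a nitro, and in this assay compound 2 gives 15.2 nM. Compound 3 therefore stands second highest of the three numbers: a 4.7-fold higher number from compound 2 to compound 3 (0.68 log units; beyond the scatter) was modest, and a 13-fold lower number from compound 1 to compound 2 (1.12 log units; beyond the scatter) was large.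

Compound 4 `CC(C)(C)c1ccc(-c2ccc(-c3ccc(C(=N)N)cc3)o2)cc1` is not yet measured. The change from compound 3 is tert-butyl in place of methyl on an aromatic carbon. Among the compounds with values here, of the measured steps only a 2.8-fold lower number from compound 1 to compound 3 (0.45 log units; beyond the scatter) bears on it, since it is the one step that changes the size of an alkyl group at this position; the nitro steps concern a different kind of group and give no guidance. Reading that modest step in reverse, a larger alkyl should raise the number, and tert-butyl is larger again than ethyl, so a step at least as large as the ethyl one is expected in this assay. The estimate for compound 4 is therefore a 3.9-fold higher number from compound 3 to compound 4 (0.59 log units; beyond the scatter), giving an expected value of 280 nM with a range from 90 nM to 900 nM.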

Compound 4, half-maximal inhibitory concentration: 510 nM
Compound 4: middle estimate off by 1.8-fold (0.26 log units), on the low side, within the range that was stated.
By their numbers in this assay, from the lowest: compound 2; then compound 3; then compound 1; then compound 4.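

Among the alkyl groups at this position in this assay, the number now rises with each enlargement, with no exception among compound 3, compound 1 and compound 4: a 2.5-fold higher number from compound 1 to compound 4 (0.40 log units; beyond the scatter) carries the rise past ethyl, and a 7.1-fold higher number from compound 3 to compound 4 (0.85 log units; beyond the scatter) spans the whole alkyl range shown. The largest alkyl group here does not remove inhibition, since compound 4 still gives a measurable 510 nM, but a 34-fold higher number from compound 2 to compound 4 (1.53 log units; beyond the scatter) sets tert-butyl and nitro at the two ends of the spread seen so far on this aromatic carbon. No measurement to hand gives a reason for the rise with alkyl size or for the low number with nitro.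

The alkyl set cannot separate carbon count from branching, and an unbranched butyl chain or an isopropyl group would be needed to tell whether tert-butyl stands high for its size or for its shape. Going by these compounds, whether the low number of compound 2 is particular to nitro remains open, as nothing yet shows how a nitrile, an amine or a carboxylic acid would read at this position.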